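A few compounds are considered here, and "the series" means these few. Any claim that something is new, unique, unknown or untested is made for them only; others in the source may bear on it.

Compound 2, `Cc1ccc(Cn2cc(COc3ccc4c(=O)ccoc4c3)nn2)cc1`, and compound 1, `Cc1cccc(Cn2cc(COc3ccc4c(=O)ccoc4c3)nn2)c1`, share one core and differ only by 4-methylphenyl in place of 3-methylphenyl on a saturated chain carbon bound to an aromatic nitrogen. In a functional assay on HeLa cells (Homo sapiens) for cytotoxicity, read by MTT assay, with a stated time of 48 h (a higher number here means a weaker inhibitor, a lower number a stronger inhibitor), compound 1 gives a value that is a limit of the assay, > 100000 nM. In this assay compound 2 likewise gives only a limit, > 100000 nM. The step that the two limits leave unreadable from compound 1 to compound 2 therefore cannot be read, since both ends sit at the limit of > 100000 nM in this assay, at which 2 of the 2 values shown sit. Compound 3, `O=c1ccoc2cc(OCc3cn(Cc4cccc(Br)c4)nn3)ccc12`, carries 3-bromophenyl in place of 4-methylphenyl on a saturated chain carbon bound to an aromatic nitrogen. Going by the values given here, no measured step bears on this change with a readable size; the only recorded step, between compound 1 and compound 2, is masked by the limits. The step that the limit leaves unreadable from compound 2 to compound 3 is expected to be nothing beyond the scatter. On that basis compound 3 in this assay is expected at 120000 nM, within 30000 nM to 500000 nM, and most likely reported once more only as a limit.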

Compound 3, half-maximal inhibitory concentration: > 100000 nM
Compound 3: no number, only a limit; the forecaster's own chance of this, stated with the estimate: 80%; the middle value does not contradict the limit.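

In this assay compound 3 gives > 100000 nM, a limit and not a number. No step among compound 1, compound 2 and compound 3 can be read: the limit of > 100000 nM in this assay, at which 3 of the 3 values shown sit.

The compounds shown leave open whether these three differ at all in this assay, and whether any change on the shared core would give a readable value there.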